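Swapping a Methoxy for an Azetidinyl on the Pyridine

A few compounds are considered here, and "the series" means these few. Any claim that something is new, unique, unknown or untested is made for them only; others in the source may bear on it.

Of the compounds shown here, two sharing one core have been measured in an in vitro assay on HEK385-7 cells for displacement of a labelled ligand from prostaglandin D2 receptor 2 (Homo sapiens); a higher number here means a weaker inhibitor, a lower number a stronger inhibitor. Compound 1 `NS(=O)(=O)c1ccc(-c2nc(C(c3ccc(F)cc3)c3ccc(F)cc3)sc2CC(=O)O)cc1` gives 1500 nM in this assay. Compound 2 `COc1cc(-c2nc(C(c3ccc(F)cc3)c3ccc(F)cc3)sc2CC(=O)O)ccn1` gives 29 nM in this assay. Among the compounds with values here, compound 2 has the lowest of the two numbers; the only step among them, a 52-fold lower number from compound 1 to compound 2 (1.71 log units; beyond the scatter), arose when a 2-methoxypyridin-4-yl replaced a 4-sulfamoylphenyl on an aromatic carbon, setting compound 2 well apart from compound 1.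

Compound 3 `O=C(O)Cc1sc(C(c2ccc(F)cc2)c2ccc(F)cc2)nc1-c1ccnc(N2CCC2)c1` has not yet been measured in this assay. Its difference from compound 2 is azetidin-1-yl in place of methoxy on an aromatic carbon, on an aromatic carbon of a six-membered aromatic ring with one nitrogen, next to the ring nitrogen. Within the data shown here, no measured step covers a change of this kind: the single known step exchanged the whole aromatic group rather than one substituent on the pyridine, so it offers no direct guide. For compound 3 the expectation is a step no larger than the scatter, a 1.0-fold higher number from compound 2 to compound 3 (0.01 log units; within the scatter), with the range widened for lack of precedent. Compound 3 is therefore estimated at 30 nM, between 8 nM and 120 nM.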

Compound 3, half-maximal inhibitory concentration: 660 nM
Beside the measured number, compound 3's estimate is 22-fold (1.34 log units) below it, and the stated range ends below it.
By their numbers in this assay, from the lowest: compound 2; then compound 3; then compound 1.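

In this assay, the group on the aromatic carbon next to the ring nitrogen matters a great deal: azetidin-1-yl in place of methoxy gives a 23-fold higher number from compound 2 to compound 3 (1.36 log units; beyond the scatter), so changing one substituent on the pyridine takes back most of what the earlier exchange of the whole aromatic group gained. The pyridine is therefore not enough on its own, as replacing 4-sulfamoylphenyl with 2-(azetidin-1-yl)pyridin-4-yl gives only a 2.3-fold lower number from compound 1 to compound 3 (0.36 log units; beyond the scatter), and the methoxy form remains far ahead of both other compounds. Nothing measured on these compounds explains this loss.

The compounds shown leave open whether the higher number goes with the attached nitrogen, the four-membered ring or simply the larger group. A dimethylamino group would keep the attached nitrogen without the ring, an ethoxy group would keep the oxygen on a longer chain, and a pyridine with only hydrogen on this carbon would show how much the methoxy itself contributes.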